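Furan-2-yl for bromo on a fused adenine core

A few compounds are considered here, and "the series" means these few. Any claim that something is new, unique, unknown or untested is made for them only; others in the source may bear on it.

The measured compounds:
compound 1 `CCCn1c(-c2ccco2)nc2c(N)nc(NCCCc3ccccc3)nc21` 230 nM
compound 2 `CCCn1cnc2c(NCc3ccccc3)ncnc21` 42800 nM
compound 3 `CCCn1c(Br)nc2c(NCCCc3ccccc3)ncnc21` 2670 nM

In an assay on CHO cells for displacement of a labelled ligand from adenosine receptor A1 (Homo sapiens) (on this read-out higher numbers stand for weaker inhibition and lower numbers for stronger inhibition), compound 3 stands second highest of the three numbers. The nearest is compound 1 at 230 nM, a gap well beyond the scatter; the furthest is compound 2 at 42800 nM. Compound 4 `CCCn1c(-c2ccco2)nc2c(NCCCc3ccccc3)ncnc21` differs from compound 3 in one place: furan-2-yl in place of bromo on an aromatic carbon. Going by the values given here, no pair measured here differs by this change alone, so the direction must be inferred from compound 1, whose furan-bearing core gives 230 nM, although compound 1 also differs elsewhere. Compound 4 is expected to show a modest gain, a step of a 3.0-fold lower number from compound 3 to compound 4 (0.47 log units; beyond the scatter) beyond the scatter. The estimate for compound 4 is 900 nM, ranging from 250 nM to 3000 nM.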

Compound 4, inhibition constant: 378 nM
Compound 4: the middle estimate sits 2.4-fold (0.38 log units) above what was measured; the range from low to high includes it.
By their numbers in this assay, from the lowest: compounds 1 and 4 (each within the scatter of the next); then compound 3; then compound 2.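

In this assay, going by these compounds alone, replacing bromo with furan-2-yl on the aromatic carbon between two ring nitrogen atoms gives a 7.1-fold lower number from compound 3 to compound 4 (0.85 log units; beyond the scatter), the first reading of this change alone on the shared core. Within the data shown here, until now the furan-2-yl group had been seen only in compound 1, which carries other differences as well. No evidence here accounts for the size of this step.

From the compounds shown here alone, whether a thiophen-2-yl or phenyl ring, or an amine, would act like furan-2-yl at this carbon remains open. So does whether the step would hold with a shorter chain on the exocyclic nitrogen.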